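Small chain change on a shared core

The source may report more compounds than this note shows. Statements on the series, on what has been measured and on what is new or still open speak of the compounds shown alone.

Measured so far in a functional assay on HeLa cells (Homo sapiens) for inhibition, read by MTT assay, with a stated time of 48 h; on this read-out lower numbers stand for stronger inhibition and higher numbers for weaker inhibition
compound 1 `O=C(CCCCOc1no[n+]([O-])c1S(=O)(=O)c1ccccc1)NO` gives 3650 nM
compound 2 `O=C(COCCOc1no[n+]([O-])c1S(=O)(=O)c1ccccc1)NO` gives 6690 nM

Going by the values given here, only two numbers exist, and the single measured step, a 1.8-fold higher number from compound 1 to compound 2 (0.26 log units; within the scatter), leaves compound 2 level with its one neighbour within ordinary repeat variation. Compound 3 `CC(C)(COc1no[n+]([O-])c1S(=O)(=O)c1ccccc1)C(=O)NO` differs from compound 2 in the same chain, with 1-(hydroxycarbamoyl)-1-methylethyl in place of ((hydroxycarbamoyl)methoxy)methyl on a saturated chain carbon bound to an oxygen on an aromatic ring. Here 1-(hydroxycarbamoyl)-1-methylethyl takes the place of ((hydroxycarbamoyl)methoxy)methyl. One small step is thin evidence, but it gives no reason to expect a change beyond the scatter in this assay. The estimated step is a 1.1-fold lower number from compound 2 to compound 3 (0.05 log units; within the scatter) in size. Compound 3 is estimated at 6000 nM, with 2500 nM to 15000 nM as its expected range.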

Compound 3, half-maximal inhibitory concentration: 6360 nM
The estimate for compound 3 lay 1.1-fold (0.03 log units) below the measured number, within the range that was stated.
By their numbers in this assay, from the lowest: compounds 1, 3 and 2 (each within the scatter of the next).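

In this assay, 1-(hydroxycarbamoyl)-1-methylethyl in place of ((hydroxycarbamoyl)methoxy)methyl gives a 1.1-fold lower number from compound 2 to compound 3 (0.02 log units; within the scatter) and, in place of 3-(hydroxycarbamoyl)propyl, gives a 1.7-fold higher number from compound 1 to compound 3 (0.24 log units; within the scatter) on the same saturated chain carbon. A branched group therefore reads alike with both unbranched chains, so none of the three changes at this position moves the number beyond the scatter. No measurement here accounts for this sameness. Still open, on these data alone, is whether a longer chain, or a carboxylic acid in place of the hydroxycarbamoyl end, would give a step beyond the scatter.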